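Swapping a vinyl for a propynyl on the amine side chain

A few compounds are considered here, and "the series" means these few. Any claim that something is new, unique, unknown or untested is made for them only; others in the source may bear on it.

Three compounds that share one core and differ only in the group on the amine nitrogen have been tested in an assay for inhibition of tRNA (cytosine(38)-C(5))-methyltransferase (Homo sapiens), with a stated time of 5 min, tested at 100 uM; on this read-out lower numbers stand for less inhibition and higher numbers for more inhibition at the one concentration tested (going by the name of the read-out). Compound 1, `CC(C)N(CC[C@H](N)C(=O)O)C[C@H]1O[C@@H](n2cnc3c(N)ncnc32)[C@H](O)[C@@H]1O`, gives 44% in this assay. Compound 2, `Nc1ncnc2c1ncn2[C@@H]1O[C@H](CN(CC[C@H](N)C(=O)O)CC2CCCC2)[C@@H](O)[C@H]1O`, gives 24.5%, and the step of a number 19.5 percentage points lower from compound 1 to compound 2 (beyond the scatter) shows that the bulkier ring-bearing group lowers the number. Compound 3, `C=CCN(CC[C@H](N)C(=O)O)C[C@H]1O[C@@H](n2cnc3c(N)ncnc32)[C@H](O)[C@@H]1O`, gives 53.9%, the highest of the three numbers, though its gap to compound 1, a number 9.9 percentage points higher from compound 1 to compound 3 (within the scatter), is within the scatter, so the two cannot be ranked against each other. Against compound 2 the step of a number 29.4 percentage points higher from compound 2 to compound 3 (beyond the scatter) is clear.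

Compound 4, `CC#CCN(CC[C@H](N)C(=O)O)C[C@H]1O[C@@H](n2cnc3c(N)ncnc32)[C@H](O)[C@@H]1O`, takes the step (prop-1-yn-1-yl in place of vinyl on a saturated chain carbon bound to an amine nitrogen). The two steps that bear on it point the same way: a small, unsaturated, chain-like group on the amine keeps the number high, as in compound 3, while a larger saturated ring lowers it, as in compound 2. The entering group is one carbon longer than the vinyl but stays unsaturated and without a ring, so only a small change is expected. Compound 4 is therefore estimated to give 48% in this assay, between 30% and 65%, a step of a number 5.9 percentage points lower from compound 3 to compound 4 (within the scatter) from compound 3 that is expected to stay within the scatter.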

Compound 4, a percentage reported as inhibition, at one concentration (the size of the read-out at that concentration, not a potency): 61.3%
The estimate for compound 4 lay 13.3 percentage points below the measured number; low and high end bracket the measured number.
By their numbers in this assay, from the lowest: compound 2; then compounds 1, 3 and 4 (each within the scatter of the next, the first and the last beyond it).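

In this assay, the step at this place reads a number 7.4 percentage points higher from compound 3 to compound 4 (within the scatter), so on a saturated chain carbon bound to an amine nitrogen, prop-1-yn-1-yl with its triple bond and one more carbon can stand in place of vinyl with no readable difference. Seen one bond further out, but-2-yn-1-yl in place of isopropyl on the amine nitrogen gives a number 17.3 percentage points higher from compound 1 to compound 4 (beyond the scatter), a gap beyond the scatter that allyl did not reach, while prop-1-yn-1-yl in place of cyclopentyl gives a number 36.8 percentage points higher from compound 2 to compound 4 (beyond the scatter), the largest step among these compounds. Nothing measured here offers a reason for these numbers.

A butyl group and the shorter prop-2-yn-1-yl group on the same nitrogen would help separate the part played by the triple bond from the part played by chain length. Going by these compounds, a longer chain such as pent-2-yn-1-yl would show whether the number holds up further out, and with a single tested concentration, the potency of all these compounds remains open.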